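This account rests on a few compounds, and the source may have more. Where it says the series, first, only, none or still open, it means among the compounds named here.

Of the compounds shown here, three sharing one core have been tested in a functional assay on TSU-Pr1 cells for antiproliferative activity against TSU (Homo sapiens), read by sulforhodamine B assay; on this read-out lower numbers stand for stronger inhibition and higher numbers for weaker inhibition. Compound 1, `CCCCCCCCCCCCCCCCCCNC(=O)[C@H]1CSC(C2CCCCC2)N1`, gives only a limit in this assay, > 20000 nM. Compound 2, `CCCCCCCCCCCCCCCCCCNC(=O)[C@H]1CSC(Cc2ccccc2)N1`, gives 11200 nM in this assay, and compound 3, `CCCCCCCCCCCCCCCCCCNC(=O)[C@H]1CSC(c2ccc(N(C)C)cc2)N1`, gives 3000 nM. Of the two numbers shown, compound 3 has the lowest; its nearest neighbour is compound 2, separated by a 3.7-fold lower number from compound 2 to compound 3 (0.57 log units; beyond the scatter), while the move from the cyclohexyl compound gave an at least 6.6-fold lower number from compound 1 to compound 3 (0.82 log units; beyond the scatter). Compound 4, `CCCCCCCCCCCCCCCCCCNC(=O)[C@H]1CSC(c2cccc(O)c2)N1`, is not yet measured; it differs from compound 3 in that (3-hydroxyphenyl in place of 4-(dimethylamino)phenyl on a saturated ring carbon). For the measured compounds named here, both measured steps that bear on this change ended at compound 3, which carries the 4-(dimethylamino)phenyl group, and no measured compound carries a 3-hydroxyphenyl group, so the direction rests on thin ground. Some loss of the gain seen in compound 3 is expected, so the estimated step is a 2.0-fold higher number from compound 3 to compound 4 (0.30 log units; within the scatter). Compound 4 is therefore expected to give 6000 nM in this assay, within a range of 2500 nM to 15000 nM.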

Compound 4, half-maximal inhibitory concentration: 4000 nM
Compound 4: the middle estimate sits 1.5-fold (0.18 log units) above what was measured, and the stated range covers the measured number.
By their numbers in this assay, from the lowest: compounds 3 and 4 (each within the scatter of the next); then compound 2. At a limit, above all of these: compound 1.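

In this assay, the 3-hydroxyphenyl group at this saturated ring carbon does about as well as the 4-(dimethylamino)phenyl group: the swap gives a 1.3-fold higher number from compound 3 to compound 4 (0.12 log units; within the scatter), so the two groups cannot be told apart here. The new group also clearly improves on benzyl, with a 2.8-fold lower number from compound 2 to compound 4 (0.45 log units; beyond the scatter), which means that two quite different substituted phenyl groups now give lower numbers than benzyl. Against the cyclohexyl group the change gives an at least 5.0-fold lower number from compound 1 to compound 4 (0.69 log units; beyond the scatter), which is only a floor, since compound 1 stands at a limit: the limit of > 20000 nM in this assay, at which 1 of the 4 values shown sits.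

The swap changes both the substituent and its place on the phenyl ring, and the compounds shown cannot separate the two. From the compounds shown here alone, how a plain phenyl group, a 4-hydroxyphenyl group or a phenyl ring bearing a carboxylic acid would compare remains open.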